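A few compounds are considered here, and "the series" means these few. Any claim that something is new, unique, unknown or untested is made for them only; others in the source may bear on it.

Compound 2 `Cc1nn(-c2ncnc3nc[nH]c23)c2c1C(OCc1ccccc1Cl)CC(=O)N2` shares its core with compound 1 `Cc1nn(-c2ncnc3nc[nH]c23)c2c1C(OCc1cc(F)cc3c1OCOC3)CC(=O)N2`, the two differing only in the group on the saturated chain carbon bound to an oxygen on a saturated carbon. In a functional assay on HEK293 cells for agonist activity at G-protein coupled receptor 39 (Homo sapiens), read by scintillation proximity assay and inositol phosphate accumulation, with a stated time of 75 min, in the presence of a further agent that is not named here (a lower number here means that less compound is needed, a higher number that more compound is needed for the effect), compound 1 gives 1.5 nM and compound 2 gives 2 nM; compound 2 has the higher of the two numbers, but the step of a 1.3-fold higher number from compound 1 to compound 2 (0.12 log units; within the scatter) lies within the scatter, so the two are not told apart. Compound 3 `Cc1nn(-c2ncnc3nc[nH]c23)c2c1C(NC(=O)Cc1cccs1)CC(=O)N2` carries the change ((((thiophen-2-yl)methyl)carbonyl)amino in place of (2-chlorobenzyl)oxy on a saturated ring carbon). Within the data shown here, only one measured step bears on this position, and it exchanged one aryl group for another while keeping the ether link, so the swap of the ether for an amide with a thiophene has no direct precedent here. A loss beyond the scatter is expected for compound 3, whose value in this assay is estimated at 10 nM, in the range 2 nM to 60 nM. The expected step is a 5.0-fold higher number from compound 2 to compound 3 (0.70 log units; beyond the scatter).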

Compound 3, half-maximal effective concentration: 3 nM
The estimate for compound 3 lay 3.3-fold (0.52 log units) above the measured number, and the stated range covers the measured number.
By their numbers in this assay, from the lowest: compounds 1, 2 and 3 (each within the scatter of the next).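

In this assay, (((thiophen-2-yl)methyl)carbonyl)amino in place of (2-chlorobenzyl)oxy on a saturated ring carbon gives a 1.5-fold higher number from compound 2 to compound 3 (0.18 log units; within the scatter), so the two are not told apart. The earlier step kept the ether link, whereas this one replaces both the link and the aromatic ring and adds a hydrogen-bond donor, so this position admits an amide link with a thiophene as well as an ether link with a benzene ring, without a step beyond the scatter. No measurement at hand gives a reason for this result.

The link and the ring change together in this step, so the share of each stays unresolved. Also open, as far as these compounds go, is how the number responds to a free amine or a carboxylic acid on this carbon, or to a longer chain between the carbonyl and the thiophene.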